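Predicting Gastric Inhibition After Replacing Bromo With an Ester

The source may hold more compounds than are shown below. What is called first, only, known or untested is meant among the compounds shown, and "the series" means these compounds.

Compound 2 `Cc1nc2c(OCc3ccccc3)cccn2c1Br` stands highest of the two compounds measured in a functional assay on the whole organism (stomach) for inhibition, with Canis familiaris (Canis lupus familiaris) as the target, at a dose of 5 mg/kg by the intravenous route; a lower number here means a weaker effect, a higher number a stronger effect of the compound at the dose given: compound 2 gives 63%, whereas compound 1 `Cc1nc2c(OCc3ccccc3)cccn2c1C(N)=O` gives 2%. Among the measured compounds shown here, the single known step, a number 61 percentage points higher from compound 1 to compound 2 (beyond the scatter), shows that the group on this aromatic carbon of the shared core has a large influence on the read-out. Compound 3 `CCCCC(=O)OCc1c(C)nc2c(OCc3ccccc3)cccn12` differs from compound 2 by ((butylcarbonyl)oxy)methyl in place of bromo on an aromatic carbon. The measured step concerns the same carbon but exchanges different groups, so it cannot fix the direction for compound 3; it does indicate that any change at this carbon can move the number well beyond the scatter. For the measured compounds named here, with only one comparison available, the estimate for compound 3 is set as a downward step, a number 23 percentage points lower from compound 2 to compound 3 (beyond the scatter), carrying wide uncertainty. Compound 3 is therefore expected to give 40% in this assay, within a range from 8% to 75%.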

Compound 3, a percentage reported as inhibition, in the whole organism at one dose (the size of the read-out at that dose, not a potency): 96%
Compound 3: middle estimate off by 56 percentage points, on the low side, outside the stated range (above it).
By their numbers in this assay, from the lowest: compound 1; then compound 2; then compound 3.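

In this assay, putting ((butylcarbonyl)oxy)methyl in place of bromo gives a number 33 percentage points higher from compound 2 to compound 3 (beyond the scatter), so bromo does not mark the top of the range at this aromatic carbon. Against carbamoyl, the same group gives a number 94 percentage points higher from compound 1 to compound 3 (beyond the scatter), which places the three groups at this one carbon in the order carbamoyl, bromo, ((butylcarbonyl)oxy)methyl, and shows that an entering group of 8 heavy atoms is compatible with a strong effect at the dose given. No measurement at hand explains this gain. The compounds shown leave open whether the gain depends on the whole ester or on one part of it, which a plain hydroxymethyl, an acetyloxymethyl or a longer acyl chain at this carbon would help to separate. They also leave open how the effect of compound 3 changes at other doses.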